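Adding an amino group to compound 1

The source may hold more compounds than are shown below. What is called first, only, known or untested is meant among the compounds shown, and "the series" means these compounds.

Values measured in an ADME assay on a cell-free system (plasma, Mus musculus) for metabolic stability, read by HPLC, with a stated time of 120 min, tested at 2 uM (on this read-out lower numbers stand for a shorter-lived compound and higher numbers for a longer-lived compound), are as follows
Compound 1 `Cc1cccc(CNC(=O)n2cnc3ccccc32)c1` gives 1.18 h
Compound 2 `O=C(NCCCCc1ccccc1)n1c(=O)n(C(=O)NCCCCc2ccccc2)c2ccccc21` gives > 2 h
Compound 3 `CCCCCCNC(=O)N1C(=O)c2ccccc2C1=O` gives 0.483 h

The entry of compound 2 (> 2 h) is a limit of the assay and not a number. Of the two actual numbers, compound 1 (1.18 h) is the higher, and compound 3 (0.483 h) lies lower by a gap beyond the usual scatter.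

Compound 4 `Cc1cccc(CNC(=O)n2c(N)nc3ccccc32)c1` has not yet been measured. It differs from compound 1 by a single change (amino in place of hydrogen on an aromatic carbon), with amino in place of hydrogen on an aromatic carbon, between two ring nitrogen atoms and next to the ring atom that bears a large group. Within the data shown here, the measured compounds include no step of this kind, so the data give no size for it. In this assay no step beyond the scatter is expected, and if anything a slightly longer half-life. The expected step (a 1.3-fold higher number from compound 1 to compound 4 (0.10 log units; within the scatter)) therefore stays within the scatter. For compound 4 the estimated half-life is 1.5 h with an expected range from 0.7 h to 3.2 h once it is measured.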

Compound 4, half-life: < 0.0834 h
Compound 4: a limit, no number; the forecaster's own chance of this, stated with the estimate: 25%; at least 17-fold (1.25 log units) between middle value and limit.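

In this assay, among these compounds, the place between two ring nitrogen atoms, next to the ring atom that bears a large group, proves highly sensitive: amino in place of hydrogen on an aromatic carbon gives an at least 14-fold lower number from compound 1 to compound 4 (1.15 log units; beyond the scatter), a change the earlier compounds could not reveal because they offered no single-place step. The entry for compound 4 is a limit of the assay and not a number: the limit of < 0.0834 h in this assay, at which 1 of the 4 values shown sits. Even so, this shows that a single added heavy atom at this place can shift the half-life beyond the scatter.

The compounds shown leave open whether this shortening is specific to the amino group or would also follow from a hydroxyl or methoxy group at the same place. They also leave open whether a dimethylamino group there would behave as the amino group does.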